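Working notes on a three-compound growth-inhibition series

A few compounds are considered here, and "the series" means these few. Any claim that something is new, unique, unknown or untested is made for them only; others in the source may bear on it.

Measured in a functional assay on the whole organism for inhibition, with Brassica rapa subsp. chinensis as the target, with a stated time of 3 days, tested at 100 ppm; a lower number here means less inhibition of growth, a higher number more inhibition of growth at the concentration tested:
compound 1, `CCCCCCNC(=O)/C=C/c1ccccc1`, gives 82%
compound 2, `CCCCCNC(=O)/C=C/c1ccccc1`, gives 76%
compound 3, `CC(C)OC(=O)/C=C/c1ccccc1`, gives 2%

Compound 1 and compound 2 share a core and differ by methyl in place of hydrogen on a saturated chain carbon, five bonds along the chain from an amide-type nitrogen. The step of a number 6 percentage points higher from compound 2 to compound 1 (within the scatter) lies within the scatter, so the two values are treated as alike. Compound 3 stands on a different core; the difference between the two cores is not broken down here. Its value is the lowest of the three, far beyond the scatter from compound 2 and from compound 1.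

Compound 4, `CCC(C)OC(=O)/C=C/c1ccccc1`, is not yet measured. It differs from compound 3 by methyl in place of hydrogen on a saturated chain carbon, two bonds along the chain from an oxygen next to a carbonyl group. This is the same kind of change as from compound 2 to compound 1, not the same change: there the methyl enters five bonds along the chain from an amide-type nitrogen, here two bonds along the chain from an oxygen next to a carbonyl group.

The expectation for compound 4 rests on the near-zero reading of compound 3, 2%, and on the fact that the same kind of change gave only a number 6 percentage points higher from compound 2 to compound 1 (within the scatter). Compound 4 is expected to move by a number 3 percentage points higher from compound 3 to compound 4 (within the scatter). Compound 4 is estimated at 5%, between 0% and 20%.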

Compound 4, percent growth inhibition at one concentration: 20%
The estimate for compound 4 lay 15 percentage points below the measured number; the range from low to high includes it.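

In this assay the new methyl-for-hydrogen step reads a number 18 percentage points higher from compound 3 to compound 4 (beyond the scatter) and so lies clear of the scatter on its own, yet it does not separate from the earlier step: the same change on two cores in this assay, a number 6 percentage points higher (within the scatter) from compound 2 to compound 1 and a number 18 percentage points higher (beyond the scatter) from compound 3 to compound 4, 12 percentage points apart, within the scatter of two such steps. This gives no ground for treating the change as behaving differently on the two cores. It does not show that the change carries over unaltered: each core offers a single pair, and the methyl enters at a different place on each, five bonds along the chain from an amide-type nitrogen on one and two bonds along the chain from an oxygen next to a carbonyl group on the other.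

The compounds shown leave open how a longer chain, a hydroxyl or an amine in place of the sec-butyl group would read in this series. Also open, on these data alone, is how the step reads on the core of compound 1 with the methyl at the place it takes in compound 4.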